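A few compounds are considered here, and "the series" means these few. Any claim that something is new, unique, unknown or untested is made for them only; others in the source may bear on it.

Of the compounds shown here, three on the shared core have been measured. Compound 1 `CCN(CC)CN1C(=O)/C(=N\c2nc3ccc(C)cc3s2)c2c(Br)cccc21` gives 28700 nM in a functional assay on MDA-MB-231 cells (Homo sapiens) for cytotoxicity, read by sulforhodamine B assay, with a stated time of 48 h; a higher number here means a weaker inhibitor of growth, a lower number a stronger inhibitor of growth. Compound 2 `Cc1ccc2nc(/N=C3\C(=O)N(CN(C)C)c4cccc(Br)c43)sc2c1` gives 49000 nM in this assay, and compound 3 `Cc1ccc2nc(/N=C3\C(=O)N(CN4CCCCC4)c4cccc(Br)c43)sc2c1` gives 38300 nM. Compound 2 sits among these with gaps of a 1.7-fold higher number from compound 1 to compound 2 (0.23 log units; within the scatter) and a 1.3-fold lower number from compound 2 to compound 3 (0.11 log units; within the scatter), both within the scatter, so the three are not separated. Compound 4 `Cc1ccc2nc(/N=C3\C(=O)N(CN(C)C)c4cccc(Cl)c43)sc2c1` differs from compound 2 by chloro in place of bromo on an aromatic carbon. Going by the values given here, none of the measured steps touches this position: a 1.3-fold higher number from compound 1 to compound 3 (0.13 log units; within the scatter) and the other two vary only the amine on the chain carbon, all within the scatter. Among the compounds with values here, with no step on the halogen to rest on, no change beyond the scatter is expected. Compound 4 is estimated at 55000 nM, range 25000 nM to 120000 nM, an expected step of a 1.1-fold higher number from compound 2 to compound 4 (0.05 log units; within the scatter).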

Compound 4, concentration for 50% growth inhibition: 10900 nM
The estimate for compound 4 lay 5.0-fold (0.70 log units) above the measured number; the measured number lies below the stated range.
By their numbers in this assay, from the lowest: compound 4; then compounds 1, 3 and 2 (each within the scatter of the next).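

In this assay this aromatic carbon responds to a change of halogen: chloro in place of bromo gives a 4.5-fold lower number from compound 2 to compound 4 (0.65 log units; beyond the scatter) and so separates compound 4 from compound 2, whereas the amine steps on the chain carbon all stayed within the scatter. Even an exchange of one heavy atom for another at this position is enough to move the number. Nothing at hand gives a cause for this step.

Going by these compounds, whether the step carries over to the diethylamino and piperidin-1-yl compounds remains open. So does what fluoro, methyl or methoxy on this aromatic carbon would give.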